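Swapping a halogen on a weak indoleamine dioxygenase inhibitor

The source may hold more compounds than are shown below. What is called first, only, known or untested is meant among the compounds shown, and "the series" means these compounds.

Of the compounds shown here, two have been measured in an assay on isolated protein for inhibition of Indoleamine 2,3-dioxygenase 1 (Homo sapiens), read by spectrophotometry; a lower number here means a stronger inhibitor, a higher number a weaker inhibitor. Compound 1 `CC(C(=O)c1cc2ccccc2[nH]1)c1cccnc1` gives 141000 nM in this assay. Compound 2 `O=C(Cc1cccnc1)c1cc2cc(F)ccc2[nH]1` gives 36000 nM in this assay, the lowest of the two numbers shown; compound 1 stands at a higher number, a gap that lies beyond the usual scatter. The two compounds differ in more than one place, so no single step can be read from them.

Compound 3 `O=C(Cc1cccnc1)c1cc2cc(Br)ccc2[nH]1` is not yet measured. It differs from compound 2 in one place only: bromo in place of fluoro on an aromatic carbon. Among the measured compounds shown here, nothing among the measured compounds shows what this kind of swap does here, so the expectation rests on the fact that a halogen is exchanged for another halogen at the same place, with no change in ring count, donors or acceptors. A small step in this assay is expected from compound 2 to compound 3, a 1.8-fold lower number from compound 2 to compound 3 (0.26 log units; within the scatter), leaning toward a somewhat lower number, though a result within the scatter would not surprise. Compound 3 is therefore estimated at 20000 nM in this assay, within a range from 5000 nM to 80000 nM.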

Compound 3, half-maximal inhibitory concentration: 18000 nM
Estimate against measurement, compound 3: 1.1-fold (0.05 log units) above; low and high end bracket the measured number.
By their numbers in this assay, from the lowest: compounds 3 and 2 (each within the scatter of the next); then compound 1.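

In this assay, bromo in place of fluoro on an aromatic carbon gives a 2.0-fold lower number from compound 2 to compound 3 (0.30 log units; within the scatter), so at this position the two halogens cannot be told apart beyond the usual scatter of repeated measurements. Among the compounds shown here, this is the first change that can be read on its own, since compound 1 differs from compound 2 in more than one place and offered no view of this position. It suggests only that, for this pair, a larger halogen atom at this place is tolerated without a clear loss, while nothing shown accounts for that outcome.

The compounds shown leave open what chloro, iodo or a plain hydrogen at this place would do, and so whether a halogen here matters at all. They also leave open whether a quite different group at the same position, such as an amine, a methoxy group or a carboxylic acid, would move the number further than the exchange of one halogen for another.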